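The source may report more compounds than this note shows. Statements on the series, on what has been measured and on what is new or still open speak of the compounds shown alone.

Of the compounds shown here, three have so far been measured in an ADME assay on Huh-7 cells (Homo sapiens) for cytotoxicity; on this read-out lower numbers stand for stronger inhibition and higher numbers for weaker inhibition. Compound 1 `CN(c1cc2ncc(=O)[nH]c2cc1NC(=N)NCc1ccc(OC(F)(F)F)cc1)C1CCCCC1` gives 3700 nM. Compound 2 `CN(c1cc2ncc(=O)[nH]c2cc1Nc1nc(-c2ccccc2)cs1)C1CCCCC1` gives 62500 nM. Compound 3 `CN(c1ccccc1)c1cc2ncc(=O)[nH]c2cc1Nc1nc(-c2ccccc2)cs1` gives 15900 nM, the second highest of the three numbers: compound 2 sits above it and compound 1 below it, and both gaps lie beyond the scatter of repeated measurements.

Compound 2 and compound 3 differ only in the group carried on a nitrogen on an aromatic ring, and there a 3.9-fold lower number from compound 2 to compound 3 (0.59 log units; beyond the scatter). So the group on that nitrogen clearly matters in this assay.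

Compound 4 `CN(C)c1cc2ncc(=O)[nH]c2cc1Nc1nc(-c2ccccc2)cs1` has not yet been measured. It differs from compound 3 in exactly one place: methyl in place of phenyl on a nitrogen on an aromatic ring. Among the compounds with values here, no measured pair shows this particular exchange, so the only guide is the step from compound 2 to compound 3, which swapped one six-membered ring for another on the same nitrogen and moved the number by a modest amount. Removing the ring altogether is a different kind of change, and its direction cannot be read from the data with confidence; a drift back toward higher numbers, nearer the value of compound 2, seems somewhat more likely than a further fall.

Compound 4 is therefore expected to give roughly 30000 nM in this assay, with a plausible range from 10000 nM to 90000 nM. The expected step, a 1.9-fold higher number from compound 3 to compound 4 (0.28 log units; within the scatter), is an estimate with wide uncertainty.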

Compound 4, half-maximal inhibitory concentration: 57500 nM
Beside the measured number, compound 4's estimate is 1.9-fold (0.28 log units) below it; the measured number falls inside the stated range.
By their numbers in this assay, from the lowest: compound 1; then compound 3; then compounds 4 and 2 (each within the scatter of the next).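

Replacing phenyl with methyl on this nitrogen in this assay reverses the earlier drop, with a 3.6-fold higher number from compound 3 to compound 4 (0.56 log units; beyond the scatter). The comparison between methyl and cyclohexyl gives a 1.1-fold lower number from compound 2 to compound 4 (0.04 log units; within the scatter), so a small methyl and a six-membered saturated ring cannot be told apart here, and only the phenyl of compound 3 stands out among these three groups, which shows that having a ring on this nitrogen is not enough by itself to lower the number. No measurement available here accounts for why phenyl separates from the other two groups.

As far as these compounds go, since the separation rests on a single aromatic group, it remains open whether it belongs to phenyl specifically or would extend to other aromatic rings, such as a pyridyl ring or a phenyl ring carrying a chlorine or a methoxy group. From the compounds shown here alone, it is also open how the number would respond to a benzyl group on this nitrogen, which places a methylene between the nitrogen and the aromatic ring, or to an open chain such as ethyl or butyl.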